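A piperazine substituent swap in a benzamide series

The source may hold more compounds than are shown below. What is called first, only, known or untested is meant among the compounds shown, and "the series" means these compounds.

Of the compounds shown here, three of a shared core have been tested in a functional assay on MGC-803 cells (Homo sapiens) for antiproliferative activity, read by CCK-8 assay, with a stated time of 72 h, tested at 2 uM; a higher number here means a stronger effect of the compound at the concentration tested, a lower number a weaker effect. Compound 1 `Nc1ccccc1NC(=O)c1ccc(CSC(=S)N2CCc3cc([N+](=O)[O-])ccc32)cc1` gives 26.8% in this assay, compound 2 `CN(Cc1cccnc1)C(=S)SCc1ccc(C(=O)Nc2ccccc2N)cc1` gives 45.9%, and compound 3 `Nc1ccccc1NC(=O)c1ccc(CSC(=S)N2CCN(c3ccncc3)CC2)cc1` gives 64.8%, the highest of the three numbers. The gap from compound 3 to compound 2 lies beyond the scatter. The gap from compound 3 to compound 1 also lies beyond the scatter and is larger still. Compound 3 stands alone at the top of the set.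

Compound 4 `Nc1ccccc1NC(=O)c1ccc(CSC(=S)N2CCN(Cc3cccnc3)CC2)cc1` has not yet been measured. It differs from compound 3 in one place: (pyridin-3-yl)methyl in place of pyridin-4-yl on an amine nitrogen in a ring. Among the compounds with values here, no step between two measured compounds isolates this change, so its effect can only be guessed from the whole set. Compound 2 also carries a (pyridin-3-yl)methyl group on an amine nitrogen and sits with 45.9% below compound 3, which suggests a downward step of modest size, close to the edge of the scatter. Compound 4 is therefore expected to give about 52%, in a range from 32% to 70%, an estimated step of a number 12.8 percentage points lower from compound 3 to compound 4 (beyond the scatter).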

Compound 4, a percentage reported as inhibition, at one concentration (the size of the read-out at that concentration, not a potency): 37.7%
For compound 4 the middle estimate is 14.3 percentage points above the measured one; the measured number falls inside the stated range.
By their numbers in this assay, from the lowest: compound 1; then compounds 4 and 2 (each within the scatter of the next); then compound 3.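

The change on the amine nitrogen in the ring now has a step of its own: in this assay, (pyridin-3-yl)methyl in place of pyridin-4-yl gives a number 27.1 percentage points lower from compound 3 to compound 4 (beyond the scatter). This position therefore responds to the swap, although the group that leaves and the group that enters each hold one six-membered aromatic ring with 1 hetero atom and have the same counts of hydrogen-bond donors and acceptors. No measurement at hand explains the step.

The swap alters both the pyridine attachment point and the presence of a methylene link, so the step cannot be divided between the two. A pyridin-3-yl or a (pyridin-4-yl)methyl group on that nitrogen would separate them, while a 2-(pyridin-3-yl)ethyl chain or a plain phenyl ring would test the link and the ring nitrogen further.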